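Bromofluorophenyl on the Methylated Core: an Expected Cytotoxicity

A few compounds are considered here, and "the series" means these few. Any claim that something is new, unique, unknown or untested is made for them only; others in the source may bear on it.

Three compounds have been measured in a functional assay on A549 cells (Homo sapiens) for cytotoxicity, read by MTT assay, with a stated time of 72 h; on this read-out lower numbers stand for stronger inhibition and higher numbers for weaker inhibition:
compound 1 `O=C(Nc1ccc(Oc2ccnc3[nH]ccc23)cc1)c1nn(-c2ccc(Br)cc2F)ccc1=O` gives 26100 nM;
compound 2 `Cn1ccc2c(Oc3ccc(NC(=O)c4nn(-c5ccc(Cl)cc5)ccc4=O)cc3)ccnc21` gives > 60000 nM;
compound 3 `Cn1ccc2c(Oc3ccc(NC(=O)c4nn(-c5ccccc5)ccc4=O)cc3)ccnc21` gives 51700 nM.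

The value of compound 2 is a limit of the assay, not a number, namely (the limit of > 60000 nM in this assay, at which 1 of the 3 values shown sits). Among the compounds with values here, compound 3 and compound 1 therefore supply the only two numbers, and they lie within the usual scatter of each other, so neither stands apart.

Compound 4 `Cn1ccc2c(Oc3ccc(NC(=O)c4nn(-c5ccc(Br)cc5F)ccc4=O)cc3)ccnc21` keeps the core of compound 3 and changes one group: 4-bromo-2-fluorophenyl in place of phenyl on an aromatic nitrogen. Within the data shown here, one measured step touches the same phenyl ring: an at least 1.1-fold lower number from compound 2 to compound 3 (0.06 log units; that floor lies within the scatter), a change too small to stand out from the scatter. Compound 1 carries the same 4-bromo-2-fluorophenyl as compound 4 but differs from compound 3 in a second place as well, so its number serves only as a rough guide; it too sits within the scatter of compound 3.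

The expected step is therefore small, a 1.3-fold lower number from compound 3 to compound 4 (0.11 log units; within the scatter), with no direction beyond the scatter. Compound 4 is estimated at 40000 nM, between 18000 nM and 75000 nM.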

Compound 4, half-maximal inhibitory concentration: 35700 nM
Estimate against measurement, compound 4: 1.1-fold (0.05 log units) above; the measured number falls inside the stated range.
By their numbers in this assay, from the lowest: compounds 1, 4 and 3 (each within the scatter of the next). At a limit, above all of these: compound 2.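

Two single changes can now be read in this assay: on the shared core, the swap on the aromatic nitrogen gives a 1.4-fold lower number from compound 3 to compound 4 (0.16 log units; within the scatter), and with 4-bromo-2-fluorophenyl held fixed, the methyl on the other aromatic nitrogen gives a 1.4-fold higher number from compound 1 to compound 4 (0.14 log units; within the scatter), so neither change stands out from the scatter. Compound 2 gives a limit of the assay, not a number: the limit of > 60000 nM in this assay, at which 1 of the 4 values shown sits. Its comparison with the new compound therefore gives only a floor, an at least 1.6-fold lower number from compound 2 to compound 4 (0.22 log units; that floor lies within the scatter), and that too separates nothing.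

The numbers shown give no single change that stands beyond the scatter, so it remains open whether any group on this phenyl ring can do so. An amine or a carboxylic acid on that ring, or a longer chain in place of the methyl, would test this.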